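The source may hold more compounds than are shown below. What is called first, only, known or untested is meant among the compounds shown, and "the series" means these compounds.

Three compounds share one core and differ only in the group carried on an amine nitrogen in a ring. Compound 1 `Nc1ccccc1NC(=O)c1ccc(CSC(=S)N2CCN(Cc3ccccn3)CC2)cc1` gives 14.2% in a functional assay on HeLa cells (Homo sapiens) for antiproliferative activity, read by CCK-8 assay, with a stated time of 72 h, tested at 2 uM; a higher number here means a stronger effect of the compound at the concentration tested, a lower number a weaker effect. Compound 2 `Nc1ccccc1NC(=O)c1ccc(CSC(=S)N2CCN(C(c3ccccc3)c3ccccc3)CC2)cc1` gives 8% in the same test. Compound 3 `Nc1ccccc1NC(=O)c1ccc(CSC(=S)N2CCN(c3ccncc3)CC2)cc1` gives 77%, the highest of the three numbers; its nearest neighbour is compound 1, and the gap to compound 2 is larger still. Within the data shown here, the one measured single change, a number 62.8 percentage points higher from compound 1 to compound 3 (beyond the scatter), shows how strongly this position can move the read-out.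

Compound 4 `Nc1ccccc1NC(=O)c1ccc(CSC(=S)N2CCN(c3cccnc3)CC2)cc1` is the next step. It differs from compound 3 by pyridin-3-yl in place of pyridin-4-yl on an amine nitrogen in a ring. Among the measured compounds shown here, no measured pair shows the effect of shifting the ring nitrogen alone, so the only guide is that compound 3 sits far above compounds 1 and 2 and that the large step from compound 1 to compound 3 was driven by what sits at this position. Some loss is expected, but not a return to the low numbers of compounds 1 and 2, giving an estimated step of a number 22 percentage points lower from compound 3 to compound 4 (beyond the scatter). Compound 4 is therefore expected to give about 55%, between 20% and 85%.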

Compound 4, a percentage reported as inhibition, at one concentration (the size of the read-out at that concentration, not a potency): 66.2%
For compound 4 the middle estimate is 11.2 percentage points below the measured one; the measured number falls inside the stated range.
By their numbers in this assay, from the lowest: compounds 2 and 1 (each within the scatter of the next); then compound 4; then compound 3.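

In this assay, moving only the ring nitrogen from pyridin-4-yl to pyridin-3-yl gives a number 10.8 percentage points lower from compound 3 to compound 4 (beyond the scatter), so this position responds to a modest degree even when the group keeps the same atoms and the same counts. The step of a number 52 percentage points higher from compound 1 to compound 4 (beyond the scatter) is large, which shows that the high number is not confined to pyridin-4-yl: a second pyridine group attached to the amine nitrogen also stands well above compound 1. Nothing shown explains either step.

Compound 1 also differs from compound 4 in where its ring nitrogen lies. The data do not show how much of the step goes with the connecting methylene. Pyridin-2-yl attached to the same amine nitrogen could separate those two changes, while a plain phenyl ring would test whether a ring nitrogen is needed at all.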